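The source may report more compounds than this note shows. Statements on the series, on what has been measured and on what is new or still open speak of the compounds shown alone.

Working notes on the series. Compound 1 `Fc1ccccc1Nc1nc2nonc2nc1Nc1cccc(OC(F)(F)F)c1` carries trifluoromethoxy on its aniline; compound 2 `Fc1ccccc1Nc1nc2nonc2nc1Nc1ccc(OC(F)(F)F)cc1` is built from the same atoms joined differently, and the difference between the two cores is not broken down here. In an assay on mitochondria from L6 cells (Rattus norvegicus) for activation, with a stated time of 90 min (on this read-out higher numbers stand for an effect only at larger amounts of compound and lower numbers for an effect already at smaller amounts), compound 1 gives 600 nM. In this assay compound 2 gives 1300 nM, the highest of the two numbers, and the gap to compound 1 lies beyond the scatter. Compound 3 `Fc1ccccc1Nc1nc2nonc2nc1Nc1cccc(C(F)(F)F)c1` differs from compound 1 by trifluoromethyl in place of trifluoromethoxy on an aromatic carbon. In this assay compound 3 gives < 1000 nM, which is a limit of the assay and not a number. The step that the limit leaves unreadable from compound 1 to compound 3 cannot be read because the limit of < 1000 nM in this assay, at which 1 of the 3 values shown sits, stands where a value would be.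

Compound 4 `Fc1ccccc1Nc1nc2nonc2nc1Nc1ccc(C(F)(F)F)cc1` differs from compound 2 by trifluoromethyl in place of trifluoromethoxy on an aromatic carbon. This is the same kind of change as that from compound 1 to compound 3, but the place differs: meta to a large group there, para to a large group here. The step from compound 2 to compound 4 is expected to be small, a 1.4-fold lower number from compound 2 to compound 4 (0.16 log units; within the scatter). The unreadable a step that the limit leaves unreadable from compound 1 to compound 3 gives no ground to expect more. For compound 4 the estimate is 900 nM, between 300 nM and 2500 nM, resting on compound 2 and its 1300 nM.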

Compound 4, half-maximal effective concentration: 270 nM
Beside the measured number, compound 4's estimate is 3.3-fold (0.52 log units) above it; the measured number lies below the stated range.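

In this assay, trifluoromethyl in place of trifluoromethoxy on an aromatic carbon, para to a large group, gives a 4.8-fold lower number from compound 2 to compound 4 (0.68 log units; beyond the scatter), so in this one setting the change goes with a lower number, and by more than the scatter. Compound 3 gives < 1000 nM, which is a limit of the assay and not a number, so the matching step from compound 1, the same change on the other core, cannot be read: the limit of < 1000 nM in this assay, at which 1 of the 4 values shown sits. The series therefore holds a single readable case of this change, which shows what it does on the core of compound 2 and does not show whether the same lower number carries over to the core of compound 1.

The compounds shown leave open how far the result depends on trifluoromethyl itself, as no other group stands in that place, such as a nitrile, an amine or a carboxylic acid. They also leave open whether a longer chain ending in fluorine would follow trifluoromethyl or trifluoromethoxy in this assay.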